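Bromo to phenyl swap on the sulfonamide arene

The compounds below may be only part of what the source reports. "The series", "measured", "known", "first", "only" and "open" are said of these compounds alone.

Of the compounds shown here, three have been measured: compound 1 `O=S(=O)(NCCCCCCCn1cc(-c2cccnc2)nn1)c1ccccc1Br`, compound 2 `O=S(=O)(NCCCCCCn1cc(-c2cccnc2)nn1)c1ccccc1Br` and compound 3 `O=S(=O)(NCCCCCCCn1cc(-c2cccnc2)nn1)c1ccccc1-c1ccccc1`. In a functional assay on SH-SY5Y cells (Homo sapiens) for cytotoxicity, read by MTT assay, with a stated time of 56 h (a higher number here means that more compound is needed for the effect, a lower number that less compound is needed), compound 1 gives 162 nM, compound 2 gives 175 nM and compound 3 gives 99.2 nM. Compound 2 carries the highest of the three numbers, but its gaps to compound 1 and to compound 3 are both within the scatter, so no ordering among the three can be claimed.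

The difference between the cores of compound 1 and compound 2 is not broken down here; their two numbers in this assay sit close together.

Compound 3 differs from compound 1 in one place, (phenyl in place of bromo on an aromatic carbon). In this assay this produced a 1.6-fold lower number from compound 1 to compound 3 (0.21 log units; within the scatter).

Compound 4 `O=S(=O)(NCCCCCCn1cc(-c2cccnc2)nn1)c1ccccc1-c1ccccc1` is the not yet measured partner of compound 2 and differs from it by phenyl in place of bromo on an aromatic carbon. The place is described in the same words for both pairs, so the change from compound 2 to compound 4 is the same kind of change as that from compound 1 to compound 3, applied to the other core.

The expected step in this assay is a 1.6-fold lower number from compound 2 to compound 4 (0.20 log units; within the scatter), because a 1.6-fold lower number from compound 1 to compound 3 (0.21 log units; within the scatter) was the outcome of the same change, and a single precedent within the scatter supports only a small shift. Compound 4 is therefore estimated at 110 nM in this assay. For compound 4 the likely range runs from 55 nM to 220 nM.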

Compound 4, half-maximal effective concentration: 100 nM
Compound 4: the middle estimate sits 1.1-fold (0.04 log units) above what was measured, within the range that was stated.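

In this assay, phenyl in place of bromo on an aromatic carbon gives a 1.8-fold lower number from compound 2 to compound 4 (0.24 log units; within the scatter). Set beside the earlier step, the change reads the same on both cores, with no difference between the two steps that can be told apart: the same change on two cores in this assay, a 1.6-fold lower number (0.21 log units; within the scatter) from compound 1 to compound 3 and a 1.8-fold lower number (0.24 log units; within the scatter) from compound 2 to compound 4, 1.1-fold (0.03 log units) apart, within the scatter of two such steps. This shows that, for these two pairs, the swap carries from one core to the other without any detectable dependence on the core; it does not show that the swap itself has a real effect, as each step on its own lies within the scatter, and two pairs in one cell assay give no basis for a rule covering other cores or other read-outs.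

The compounds shown leave open whether any other group at this place, such as a methoxy, an amine or a carboxylic acid, would give a step beyond the scatter, and so a clearer test of whether such steps carry between cores. Also open, going by these compounds, is how the swap would read on a core with a markedly shorter or longer chain than those of compound 1 and compound 2.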